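A few compounds are considered here, and "the series" means these few. Any claim that something is new, unique, unknown or untested is made for them only; others in the source may bear on it.

Measured compounds:
compound 1 `COc1cc(NC(C)CCCNC(=O)NCc2ccncc2)c2ncccc2c1`: 20000 nM
compound 2 `COc1cc(NC(C)CCCNC(=O)NC2CCCC2)c2ncccc2c1`: 19000 nM

In a functional assay on MIA PaCa-2 cells (Homo sapiens), read by MTT assay, with a stated time of 72 h (a lower number here means a stronger inhibitor, a higher number a weaker inhibitor), compound 2 and compound 1 sit within the scatter of each other, so neither stands apart; the step of a 1.1-fold lower number from compound 1 to compound 2 (0.02 log units; within the scatter) confirms this. Compound 3 `COc1cc(NC(C)CCCNC(=O)NCC2CCCCC2)c2ncccc2c1` differs from compound 2 by cyclohexylmethyl in place of cyclopentyl on an amide-type nitrogen. Going by the values given here, the only measured step that bears on it is the one at the same amide-type nitrogen, and that step stayed within the scatter. On this basis no shift beyond the scatter is expected, and the step of no change at the digits printed from compound 2 to compound 3 (within the scatter) is estimated accordingly. Compound 3 is therefore expected at 19000 nM, within a range of 8000 nM to 45000 nM.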

Compound 3, half-maximal inhibitory concentration: 60000 nM
Estimate against measurement, compound 3: 3.2-fold (0.50 log units) below; measured number outside the range, above it.
By their numbers in this assay, from the lowest: compounds 2 and 1 (each within the scatter of the next); then compound 3.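

In this assay, the group on the amide-type nitrogen turns out to matter: cyclohexylmethyl in place of cyclopentyl gives a modest change (a 3.2-fold higher number from compound 2 to compound 3 (0.50 log units; beyond the scatter)), and cyclohexyl in place of pyridin-4-yl on a saturated chain carbon bound to that nitrogen gives a similar one (a 3.0-fold higher number from compound 1 to compound 3 (0.48 log units; beyond the scatter)). The earlier pair had shown no separation here, so this position is not indifferent to every change. No measurement at hand accounts for the shift.

Cyclohexyl directly on the amide-type nitrogen would separate ring size from the added carbon, and that remains open. Also open, going by these compounds, is how a carboxylic acid or an amine on this chain would read.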